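Chain-linked homoserine lactones: phenyl to phenethyl at the terminus

The compounds below may be only part of what the source reports. "The series", "measured", "known", "first", "only" and "open" are said of these compounds alone.

Compound 3 `O=C(CCCCCCCCc1ccccc1)N[C@H]1CCOC1=O` and compound 1 `O=C(CCCCCCCCCCc1ccccc1)N[C@H]1CCOC1=O` share a core and differ only as phenethyl in place of phenyl on a saturated chain carbon, eight bonds along the chain from a carbonyl carbon. In a functional assay on PC-3 cells (Homo sapiens) for cytotoxicity, read by sulforhodamine B assay, with a stated time of 5 days (a lower number here means a stronger inhibitor, a higher number a weaker inhibitor), compound 3 gives 67000 nM and compound 1 gives 66000 nM, a step of a 1.0-fold lower number from compound 3 to compound 1 (0.01 log units; within the scatter). Compound 2 `O=C(CCCCCCCc1ccccc1)CC(=O)N[C@H]1CCOC1=O` has a different core; the difference between the two cores is not broken down here. In this assay compound 2 gives 2000 nM, the lowest of the three numbers. Compound 4 `O=C(CCCCCCCCCc1ccccc1)CC(=O)N[C@H]1CCOC1=O` differs from compound 2 as phenethyl in place of phenyl on a saturated chain carbon, seven bonds along the chain from a carbonyl carbon. This is the same kind of change as from compound 3 to compound 1, though the place differs: seven bonds along the chain from a carbonyl carbon rather than eight. Because a 1.0-fold lower number from compound 3 to compound 1 (0.01 log units; within the scatter) lay within the scatter, a step of a 1.1-fold higher number from compound 2 to compound 4 (0.04 log units; within the scatter) is expected from compound 2 to compound 4. Compound 4 is estimated at 2200 nM, between 900 nM and 6000 nM.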

Compound 4, half-maximal inhibitory concentration: 4000 nM
Compound 4: middle estimate off by 1.8-fold (0.26 log units), on the low side; the range from low to high includes it.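

In this assay, phenethyl in place of phenyl gives a 2.0-fold higher number from compound 2 to compound 4 (0.30 log units; within the scatter). Set beside the earlier step, the change reads alike on both cores: the same change on two cores in this assay, a 1.0-fold lower number (0.01 log units; within the scatter) from compound 3 to compound 1 and a 2.0-fold higher number (0.30 log units; within the scatter) from compound 2 to compound 4, 2.0-fold (0.31 log units) apart, within the scatter of two such steps This supports carrying the change between these two cores for this one swap, with the number staying within the scatter each time, but two pairs do not show that it would carry to any other core or to another place on the chain.

Still open, on these data alone, is whether a longer chain would also stay within the scatter on either core. Also open, as far as these compounds go, is what an amine or a carboxylic acid in place of phenyl would do in this assay.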